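Replacing the Benzyl Carbamate with an Ether Chain

A few compounds are considered here, and "the series" means these few. Any claim that something is new, unique, unknown or untested is made for them only; others in the source may bear on it.

Compound 1 `CN(C)c1cc2[nH]c(C3CCCCC3)nc2cc1NC(=O)OCc1ccccc1` was tested in an ADME assay on Vero cells (Chlorocebus sabaeus) for cytotoxicity, read by resazurin assay, with a stated time of 3 days; on this read-out lower numbers stand for stronger inhibition and higher numbers for weaker inhibition. In this assay compound 1 reaches only the limit of the assay, > 100 ug/mL, and no number. Compound 2 `CCCN(CCC)c1cc2[nH]c(C3CCCCC3)nc2cc1NC(=O)OCc1ccccc1` likewise gives in this assay only the limit > 100 ug/mL. Compound 3 `CCCC(C)OC(=O)Nc1cc2nc(C3CCCCC3)[nH]c2cc1N(CC)CC` also stops at the limit > 100 ug/mL in this assay. The single step among these compounds, a step that the two limits leave unreadable from compound 1 to compound 2, cannot be read because of the limit of > 100 ug/mL in this assay, at which 3 of the 3 values shown sit. Compound 4 `CCOCCOC(=O)Nc1cc2nc(C3CCCCC3)[nH]c2cc1N(C)C` differs from compound 1 in another part of the molecule: ethoxymethyl in place of phenyl on a saturated chain carbon bound to an oxygen next to a carbonyl group. Among the measured compounds shown here, no measured pair touches this position, and every value shown sits at the limit, so nothing in the data points to a step in either direction beyond the scatter. Compound 4 is therefore expected to sit at the limit as well, with an estimate of 100 ug/mL in this assay and a range from 50 ug/mL to 200 ug/mL. The expected step of a number no higher from compound 1 to compound 4 (the limit leaves the size open) is none beyond the scatter.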

Compound 4, half-maximal inhibitory concentration: > 100 ug/mL
Compound 4 ended at the assay's limit (the forecaster's own chance of this, stated with the estimate: 85%); the middle value sits exactly at the limit.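

Among the compounds shown here, compound 1 and compound 4 each give only a limit and no number, so no step between them can be read: the limit of > 100 ug/mL in this assay, at which 4 of the 4 values shown sit. The compounds shown leave open whether benzyl to 2-ethoxyethyl changes toxicity to these cells at all, and in which direction.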